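Nitro in place of ethoxy on a scaffold at the limit

A few compounds are considered here, and "the series" means these few. Any claim that something is new, unique, unknown or untested is made for them only; others in the source may bear on it.

Compound 3 `CCOc1ccc(-n2nncc2CN2C(=O)C3(C(C#N)=C(N)Oc4c3c3nc5ccccc5nc3c3ccccc43)c3ccccc32)cc1` was tested in an ADME assay on L02 cells (Homo sapiens) for antiproliferative activity, read by MTT assay, with a stated time of 48 h (a lower number here means a stronger inhibitor, a higher number a weaker inhibitor), where compound 3 gives > 50000 nM, a limit of the assay rather than a number. Compound 1 `N#CC1=C(N)Oc2c(c3nc4ccccc4nc3c3ccccc23)C12C(=O)N(Cc1cnnn1-c1cccc(Br)c1)c1ccccc12` likewise gives > 50000 nM, also a limit. Compound 2 `COc1ccc(-n2nncc2CN2C(=O)C3(C(C#N)=C(N)Oc4c3c3nc5ccccc5nc3c3ccccc43)c3ccccc32)cc1` gives > 50000 nM, again a limit. All three values thus sit at the limit of > 50000 nM in this assay, at which 3 of the 3 values shown sit, and the steps a step that the two limits leave unreadable from compound 1 to compound 2, a step that the two limits leave unreadable from compound 1 to compound 3 and a step that the two limits leave unreadable from compound 2 to compound 3 cannot be read in size or direction. Compound 4 `N#CC1=C(N)Oc2c(c3nc4ccccc4nc3c3ccccc23)C12C(=O)N(Cc1cnnn1-c1ccc([N+](=O)[O-])cc1)c1ccccc12` differs from compound 3 by nitro in place of ethoxy on an aromatic carbon. No measured step tells how this change acts; every change shown so far left the value at the limit. Compound 4 is therefore expected to stay at the limit as well, the step that the limit leaves unreadable from compound 3 to compound 4 being an estimate only. Compound 4 is estimated at 60000 nM, between 15000 nM and 300000 nM.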

Compound 4, half-maximal inhibitory concentration: > 50000 nM
Compound 4 ended at the assay's limit; the forecaster's own chance of this, stated with the estimate: 80%; the middle value does not contradict the limit.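

In this assay compound 4 gives > 50000 nM, a limit. No step among compounds 1, 2, 3 and 4 can be read, as all four sit at that limit: the limit of > 50000 nM in this assay, at which 4 of the 4 values shown sit.

On these data alone, whether the 3-bromophenyl, 4-methoxyphenyl, 4-ethoxyphenyl or 4-nitrophenyl group makes any difference to the value stays open.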